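One Ring Swap on a Sulfur, Seen Twice

This account rests on a few compounds, and the source may have more. Where it says the series, first, only, none or still open, it means among the compounds named here.

Of the compounds shown here, three have been tested, and a fourth awaits its number. Compound 3 `Nc1nnc(SCc2coc3ccccc3c2=O)s1` carries a 5-amino-1,3,4-thiadiazol-2-yl group on a sulfur whose other neighbours are a saturated chain carbon. Compound 1 `Cc1nnc(SCc2coc3ccccc3c2=O)o1` has the same core but with 5-methyl-1,3,4-oxadiazol-2-yl in that place (5-methyl-1,3,4-oxadiazol-2-yl in place of 5-amino-1,3,4-thiadiazol-2-yl on a sulfur). Compound 2 `Cc1ccc2oc(CSc3nnc(N)s3)cc(=O)c2c1` carries the 5-amino-1,3,4-thiadiazol-2-yl group on a different core; the difference between the two cores is not broken down here. Compound 4 `Cc1ccc2oc(CSc3nnc(C)o3)cc(=O)c2c1` is compound 2 with the same change applied (5-methyl-1,3,4-oxadiazol-2-yl in place of 5-amino-1,3,4-thiadiazol-2-yl on a sulfur), on a sulfur whose other neighbours are, again, a saturated chain carbon.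

In a functional assay on HeLa cells (Homo sapiens) for cytotoxicity, read by MTT assay, with a stated time of 72 h (on this read-out higher numbers stand for weaker inhibition and lower numbers for stronger inhibition), compound 1 gives 1400 nM. In this assay compound 3 gives only a limit, > 25000 nM. In this assay compound 2 likewise gives only a limit, > 25000 nM. The measured step is an at least 17-fold lower number from compound 3 to compound 1 (1.25 log units; beyond the scatter); its size is a floor rather than a fixed number because of the limit of > 25000 nM in this assay, at which 2 of the 3 values shown sit.

The same change is now made from compound 2 to compound 4, on a place that matches word for word. If it acts as it did from compound 3 to compound 1, a step of an at least 8.3-fold lower number from compound 2 to compound 4 (0.92 log units; beyond the scatter) is expected, and compound 4 is estimated at about 3000 nM in this assay, somewhere between 800 nM and 15000 nM.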

Compound 4, half-maximal inhibitory concentration: > 25000 nM
Compound 4 ended at the assay's limit; the forecaster's own chance of this, stated with the estimate: 25%; middle value at least 8.3-fold (0.92 log units) from the limit.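

Compound 2 and compound 4 each give only a limit in this assay, not a number, so no step can be read between them: the limit of > 25000 nM in this assay, at which 3 of the 4 values shown sit.

The compounds shown leave open whether 5-methyl-1,3,4-oxadiazol-2-yl in place of 5-amino-1,3,4-thiadiazol-2-yl changes the number at all on the core of compound 2, as it does on the core of compound 1.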